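A few compounds are considered here, and "the series" means these few. Any claim that something is new, unique, unknown or untested is made for them only; others in the source may bear on it.

In a functional assay on A549 cells (Homo sapiens) for cytotoxicity, read by MTT assay, with a stated time of 72 h (on this read-out lower numbers stand for stronger inhibition and higher numbers for weaker inhibition), compound 1 `O=S(=O)(c1ccccc1)c1nc2ccccc2nc1Nc1ccc(C(F)(F)F)cc1` gives > 50000 nM, which is a limit of the assay rather than a number (the limit of > 50000 nM in this assay, at which 1 of the 3 values shown sits). Compound 2 `Cc1ccc(S(=O)(=O)c2nc3ccccc3nc2Nc2ccc(N)cc2)cc1` gives 24600 nM in this assay, and compound 3 `Cc1ccc(S(=O)(=O)c2nc3ccccc3nc2Nc2ccc(Cl)cc2)cc1` gives 54200 nM. Among the measured compounds shown here, the step of a 2.2-fold higher number from compound 2 to compound 3 (0.34 log units; beyond the scatter) is the only measured step, and it leaves compound 3 with the highest of the two numbers in this assay, with compound 2 the nearest. Compound 4 `Cc1ccc(S(=O)(=O)c2nc3ccccc3nc2Nc2ccc(C(F)(F)F)cc2)cc1` differs from compound 3 by trifluoromethyl in place of chloro on an aromatic carbon. For the measured compounds named here, no measured step covers this exchange; the step from compound 2 to compound 3 concerns a different group. What does bear on it is that compound 1 carries the same trifluoromethyl group on the same aniline ring, and compound 1 sits at the limit in this assay. Compound 4 is therefore expected to give a number near or beyond the limit, estimated at 70000 nM, between 30000 nM and 200000 nM. The step from compound 3 to compound 4 is expected to be a 1.3-fold higher number from compound 3 to compound 4 (0.11 log units; within the scatter) in this assay.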

Compound 4, half-maximal inhibitory concentration: 13500 nM
Estimate against measurement, compound 4: 5.2-fold (0.71 log units) above, outside the stated range (below it).
By their numbers in this assay, from the lowest: compounds 4 and 2 (each within the scatter of the next); then compound 3.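

On this aromatic carbon, para to a large group, the exchange of chloro for trifluoromethyl gives a 4.0-fold lower number from compound 3 to compound 4 (0.60 log units; beyond the scatter) in this assay, so this position responds to the change by more than the scatter. Trifluoromethyl and amino at the same place cannot be told apart, with a 1.8-fold lower number from compound 2 to compound 4 (0.26 log units; within the scatter). With trifluoromethyl kept in both compounds, methyl in place of hydrogen on an aromatic carbon gives an at least 3.7-fold lower number from compound 1 to compound 4 (0.56 log units; beyond the scatter), a step that starts from a limit of the assay and not from a number: the limit of > 50000 nM in this assay, at which 1 of the 4 values shown sits.

The compounds shown leave open how a carboxylic acid, a methoxy group or a longer chain would read on this same carbon. From the compounds shown here alone, it also stays open whether the step from hydrogen to methyl would be the same with chloro or amino in place of trifluoromethyl.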